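Small Step on a Weak Series: Compound 3 to Compound 4

This account rests on a few compounds, and the source may have more. Where it says the series, first, only, none or still open, it means among the compounds named here.

- compound 1 `CC(C)(C)n1cc2c(n1)C(=O)CC1(CCN(C(=O)c3cc(-c4ccccc4)nc4ccccc34)CC1)O2` gives > 10000 nM as a limit of the assay
- compound 2 `COc1ccc(-c2cc(C(=O)N3CCC4(CC3)CC(=O)c3nn(C(C)(C)C)cc3O4)c3ccccc3n2)cc1OC` gives 7130 nM
- compound 3 `CC(C)(C)n1cc2c(n1)C(=O)CC1(CCN(C(=O)c3cc(-c4ccccn4)nc4ccccc34)CC1)O2` gives 8100 nM

All three compounds were tested in a functional assay on MDA-MB-231 cells (Homo sapiens) for inhibition, read by MTT assay, with a stated time of 72 h (on this read-out lower numbers stand for stronger inhibition and higher numbers for weaker inhibition), and differ only in one group on the shared core. Compound 3 stands level with compound 2, since a 1.1-fold higher number from compound 2 to compound 3 (0.06 log units; within the scatter) is the step between them. Against compound 1, only floors are known: an at least 1.4-fold lower number from compound 1 to compound 2 (0.14 log units; that floor lies within the scatter) and an at least 1.2-fold lower number from compound 1 to compound 3 (0.09 log units; that floor lies within the scatter) are the two steps. No measured change at this carbon is therefore shown to exceed the scatter.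

Going by the values given here, compound 4 `CN1CCN(c2cc(C(=O)N3CCC4(CC3)CC(=O)c3nn(C(C)(C)C)cc3O4)c3ccccc3n2)CC1` changes the same carbon 4-methylpiperazin-1-yl in place of pyridin-2-yl on an aromatic carbon and carries a non-aromatic ring there, which none of the measured compounds has, so the range stays wide. On these steps, no shift beyond the scatter is expected. The estimate means a 1.0-fold lower number from compound 3 to compound 4 (0.01 log units; within the scatter) as the expected step. Compound 4 could also end at the limit of > 10000 nM in this assay, at which 1 of the 3 values shown sits, in this read-out. For compound 4 the estimated value is 8000 nM and the expected range runs from 3000 nM to 20000 nM in this assay as well.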

Compound 4, half-maximal inhibitory concentration: 8130 nM
Estimate against measurement, compound 4: 1.0-fold (0.01 log units) below, within the range that was stated.
By their numbers in this assay, from the lowest: compounds 2, 3 and 4 (each within the scatter of the next). At a limit, above all of these: compound 1.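

Compound 4 carries 4-methylpiperazin-1-yl, a non-aromatic ring, on the aromatic carbon next to the ring nitrogen, and in this assay the steps to it are a 1.0-fold higher number from compound 3 to compound 4 (0.00 log units; within the scatter) and a 1.1-fold higher number from compound 2 to compound 4 (0.06 log units; within the scatter). Among these compounds, then, aromatic and non-aromatic rings on this carbon read alike, and so does a ring with two nitrogens rather than one. Against compound 1 only a floor can be given, an at least 1.2-fold lower number from compound 1 to compound 4 (0.08 log units; that floor lies within the scatter), and the value of compound 1 is a limit of the assay: the limit of > 10000 nM in this assay, at which 1 of the 4 values shown sits.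

From the compounds shown here alone, whether any group on this carbon can move the number beyond the scatter stays open. A primary amine, a carboxylic acid or a longer alkyl chain at this position would test that further.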